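This account rests on a few compounds, and the source may have more. Where it says the series, first, only, none or still open, it means among the compounds named here.

Measured compounds: compound 1 `CC(C)C[C@H](N)c1cc(C(F)(F)F)ccc1N1CCN(C(=O)COc2ccc3ccccc3c2)CC1`, 2000 nM; compound 2 `COc1cc(CC(C)C(=O)N2CCN(c3ccc(C(F)(F)F)cc3[C@@H](N)CC(C)C)CC2)ccc1Cl`, 230 nM; compound 3 `Cc1ccc(OCC(=O)N2CCN(c3ccc(C(F)(F)F)cc3[C@@H](N)CC(C)C)CC2)cc1`, 4400 nM.

All numbers come from an assay on HEK293 cells for displacement of a labelled ligand from Melanocortin receptor 4 (Homo sapiens); a lower number here means a stronger inhibitor, a higher number a weaker inhibitor. Compound 3 stands highest of the three: a 2.2-fold higher number from compound 1 to compound 3 (0.34 log units; beyond the scatter), and a 19-fold higher number from compound 2 to compound 3 (1.28 log units; beyond the scatter). Compound 4 `CC(C)C[C@H](N)c1cc(C(F)(F)F)ccc1N1CCN(C(=O)COc2ccc(Cl)cc2)CC1` differs from compound 3 by chloro in place of methyl on an aromatic carbon. Going by the values given here, no measured step exchanges one substituent for another on this phenyl; the nearest comparison is a 2.2-fold higher number from compound 1 to compound 3 (0.34 log units; beyond the scatter), which replaces the whole aryl group on the oxygen and is modest. A single exchange at one aromatic carbon is expected to move the number less than that, in either direction, or not beyond the scatter. Compound 4 is therefore estimated at 3000 nM, range 1500 nM to 7000 nM, the expected step being a 1.5-fold lower number from compound 3 to compound 4 (0.17 log units; within the scatter).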

Compound 4, inhibition constant: 2900 nM
The estimate for compound 4 lay 1.0-fold (0.01 log units) above the measured number; measured number inside the range.
By their numbers in this assay, from the lowest: compound 2; then compounds 1, 4 and 3 (each within the scatter of the next, the first and the last beyond it).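

In this assay, chloro in place of methyl on an aromatic carbon, para to a large group, gives a 1.5-fold lower number from compound 3 to compound 4 (0.18 log units; within the scatter), so this pair does not separate the two groups at this position. With chloro at this position, 4-chlorophenyl in place of naphthalen-2-yl gives a 1.5-fold higher number from compound 1 to compound 4 (0.16 log units; within the scatter), while (4-chlorophenoxy)methyl in place of 1-(4-chloro-3-methoxybenzyl)ethyl gives a 13-fold higher number from compound 2 to compound 4 (1.10 log units; beyond the scatter), so the large gap to compound 2 remains. No evidence is available on the cause of these steps.

On these data alone, whether an amine, a carboxylic acid or a longer chain on this aromatic carbon would move the number beyond the scatter remains open.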